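Two Aryl Variants on a Shared Core

A few compounds are considered here, and "the series" means these few. Any claim that something is new, unique, unknown or untested is made for them only; others in the source may bear on it.

Compound 1 `CCC1=C(O)c2c(oc(-c3ccc(CBr)cc3)cc2=O)C(CC)(CC)C1=O` carries a 4-(bromomethyl)phenyl group on the shared core. In a functional assay on KB cells (Homo sapiens) for antiproliferative activity, read by sulforhodamine B assay, with a stated time of 3 days (a lower number here means that less compound is needed, a higher number that more compound is needed for the effect), compound 1 reaches only a limit of the assay, > 46.5 uM. Compound 2 `CCC1=C(O)c2c(oc(-c3cc(OC)c(OC)c(OC)c3)cc2=O)C(CC)(CC)C1=O` gives 46.7 uM in this assay. For compound 1, the limit of > 46.5 uM in this assay, at which 1 of the 2 values shown sits, marks where it sits. Compound 3 `CCC1=C(O)c2c(oc(-c3cc(C)cc(C)c3)cc2=O)C(CC)(CC)C1=O` is not yet measured; it differs from compound 1 by 3,5-dimethylphenyl in place of 4-(bromomethyl)phenyl on an aromatic carbon. Among the measured compounds shown here, with no measured step between these compounds, compound 3 is expected to show no change beyond the scatter, estimated at 40 uM with a range of 15 uM to 100 uM, the expected step being an at least 1.1-fold lower number from compound 1 to compound 3 (0.06 log units; that floor lies within the scatter).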

Compound 3, concentration for half-maximal effect: 45.5 uM
For compound 3 the middle estimate is 1.1-fold (0.06 log units) below the measured one; the range from low to high includes it.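

In this assay the change at this position from 4-(bromomethyl)phenyl to 3,5-dimethylphenyl reads as an at least 1.0-fold lower number from compound 1 to compound 3 (0.00 log units; that floor lies within the scatter) and removes the bromine. Only a floor is known, so the true step may be larger, but nothing shown places it beyond the scatter. Compound 1 stands at a limit, not a number: the limit of > 46.5 uM in this assay, at which 1 of the 3 values shown sits.

On these data alone, whether an amine or a carboxylic acid on the phenyl ring, or a longer chain in place of the methyl groups, would shift the number in this assay remains open.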